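Hydroxymethyl for cyclopropyl on the shared core of compound 1

The source may hold more compounds than are shown below. What is called first, only, known or untested is meant among the compounds shown, and "the series" means these compounds.

Measured compounds:
compound 1 `Cc1c(C2CC2)nc2ccc(-n3ccc(OCc4ccc(F)cc4)cc3=O)cn12`, in an assay on CHO cells for displacement of a labelled ligand from melanin-concentrating hormone receptor 1 (Homo sapiens), read by scintillation counting, with a stated time of 1 h (a lower number here means a stronger inhibitor, a higher number a weaker inhibitor), compound 1 gives 47 nM
compound 2 `Cc1c(C2CC2)nc2ccc(-n3ccc(OCc4ccc(C(F)(F)F)cc4)cc3=O)cn12`, in this assay compound 2 gives 72 nM

Compound 1 and compound 2 sit within the scatter of each other, the difference being a 1.5-fold higher number from compound 1 to compound 2 (0.19 log units; within the scatter). Compound 3 `Cc1c(CO)nc2ccc(-n3ccc(OCc4ccc(F)cc4)cc3=O)cn12` differs from compound 1 by hydroxymethyl in place of cyclopropyl on an aromatic carbon. Among the measured compounds shown here, no measured step touches this part of the shared core; the one measured step concerns a substituent elsewhere and gives no guide. Without a precedent, a modest weakening is expected, an estimated step of a 3.2-fold higher number from compound 1 to compound 3 (0.50 log units; beyond the scatter). Compound 3 is therefore expected at about 150 nM in this assay, within a range of 40 nM to 600 nM.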

Compound 3, half-maximal inhibitory concentration: > 1000 nM
Compound 3 ended at the assay's limit (the forecaster's own chance of this, stated with the estimate: 5%); middle value at least 6.6-fold (0.82 log units) away from the limit.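

This place on the shared core proves sensitive in this assay: hydroxymethyl in place of cyclopropyl gives an at least 21-fold higher number from compound 1 to compound 3 (1.32 log units; beyond the scatter), whereas the earlier trifluoromethyl for fluoro step stayed within the scatter. The value of compound 3 is a limit of the assay and not a number, so the full size of this step stays unknown: the limit of > 1000 nM in this assay, at which 1 of the 3 values shown sits.

Still open, from the compounds shown here alone, is whether the step goes with the loss of the three-membered ring or with the entry of the hydroxyl oxygen. An ethyl or a methoxymethyl group at this place would bear on that question.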